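Replacing an Aryl Ring with an Alkene-Linked Fluorophenyl Group

This account rests on a few compounds, and the source may have more. Where it says the series, first, only, none or still open, it means among the compounds named here.

Compound 1, `COc1ccc(-c2cc(C(C)=O)c3[nH]c(-c4ccccc4)cc3c2)cc1`, gives 30.8% in a functional assay on MCF7 cells (Homo sapiens) for cytotoxicity, read by MTT assay, with a stated time of 2 days, tested at 100 uM; a higher number here means a weaker effect of the compound at the concentration tested, a lower number a stronger effect.
Compound 2, `COc1ccc(-c2cc(C(C)=O)c3[nH]c(-c4ccc(F)cc4)cc3c2)cc1`, gives 14.8% in this assay.
Compound 3, `COc1ccc(-c2cc(C(C)=O)c3[nH]c(-c4ccc(OC)cc4)cc3c2)cc1`, gives 39.9% in this assay.

Compound 2 has the lowest number of the three: the step of a number 16 percentage points lower from compound 1 to compound 2 (beyond the scatter) placed it below compound 1, and the step of a number 25.1 percentage points higher from compound 2 to compound 3 (beyond the scatter) placed compound 3 above it, both beyond the scatter. The gap between compound 1 and compound 3, a number 9.1 percentage points higher from compound 1 to compound 3 (within the scatter), lies within the scatter.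

Compound 4, `CC(=O)c1cc(/C=C/c2ccc(F)cc2)cc2cc(-c3ccc(F)cc3)[nH]c12`, differs from compound 2 in one place: 2-(4-fluorophenyl)ethenyl in place of 4-methoxyphenyl on an aromatic carbon. Within the data shown here, no measured step bears directly on this change, since the two measured steps altered a group on the other aryl ring and left the 4-methoxyphenyl group in place. Among the measured compounds shown here, those steps show only the scale of movement seen so far in this assay, and the new group, with its double bond outside aromatic rings and no hydrogen-bond acceptor, has no precedent here. The expectation for compound 4 is therefore a step of a number 10.2 percentage points higher from compound 2 to compound 4 (beyond the scatter), wide in its uncertainty. Compound 4 is estimated at 25%, expected within 5% to 55%.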

Compound 4, a percentage reported as activity, at one concentration (the size of the read-out at that concentration, not a potency): 42.2%
Compound 4: the middle estimate sits 17.2 percentage points below what was measured; the range from low to high includes it.
By their numbers in this assay, from the lowest: compound 2; then compounds 1, 3 and 4 (each within the scatter of the next, the first and the last beyond it).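

Among these compounds, changing the group on the aromatic carbon meta to an acetyl group gives the first reading at this position, and in this assay the exchange brings a number 27.4 percentage points higher from compound 2 to compound 4 (beyond the scatter), so the effect at the concentration tested is weaker with 2-(4-fluorophenyl)ethenyl than with 4-methoxyphenyl. Among the compounds shown here, the position therefore responds to substitution, which the earlier steps on the other aryl ring could not show. The change is a composite one, however, adding a double bond outside aromatic rings and exchanging methoxy for fluoro in a single step, and nothing available explains the shift or assigns it to either part.

The compounds shown leave open how a 4-fluorophenyl group attached directly at this position would read. They also leave open how a saturated ethyl linker or a morpholine there would compare with 4-methoxyphenyl.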